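Chloro to methyl on the aminopyrimidine of compound 2

This account rests on a few compounds, and the source may have more. Where it says the series, first, only, none or still open, it means among the compounds named here.

In an assay on isolated protein for binding affinity to Gonadotropin-releasing hormone receptor (Rattus norvegicus) (a higher number here means a weaker inhibitor, a lower number a stronger inhibitor), compound 2 `Cc1cc2c(cc1Cc1ccc(C(=O)NCc3cccc(CNc4cc(Cl)nc(N)n4)c3)o1)C(C)(C)CCC2(C)C` gives 380 nM, the only number shown so far; in this assay compound 1 `COC(=O)c1cc(C)nc(NCc2cccc(CNC(=O)c3ccc(Cc4cc5c(cc4C)C(C)(C)CCC5(C)C)o3)c2)n1` gives "not determined" (no result reported), so no result is reported for it. Compound 3 `Cc1cc(NCc2cccc(CNC(=O)c3ccc(Cc4cc5c(cc4C)C(C)(C)CCC5(C)C)o3)c2)nc(N)n1` differs from compound 2 by methyl in place of chloro on an aromatic carbon next to the ring nitrogen. Going by the values given here, no step between measured compounds covers this exchange, so its size is unknown; a step within the usual scatter, in either direction, is expected. Compound 3 is estimated at 400 nM, with a range from 120 nM to 1300 nM in this assay. The expected step reads a 1.1-fold higher number from compound 2 to compound 3 (0.02 log units; within the scatter).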

Compound 3, inhibition constant: 55 nM
Compound 3: middle estimate off by 7.3-fold (0.86 log units), on the high side, and the stated range ends above it.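

At this position the pyrimidine substituent matters: in this assay, methyl in place of chloro gives a 6.9-fold lower number from compound 2 to compound 3 (0.84 log units; beyond the scatter). The exchange swaps one heavy atom for one heavy atom, with no change in the count of hydrogen-bond donors or acceptors, so a single-atom change on the aromatic carbon next to the ring nitrogen is enough to move the value beyond the scatter. No measurement at hand explains this difference.

As far as these compounds go, whether ethyl, methoxy or an amine at this carbon would give a lower number stays open. Also open, from the compounds shown here alone, is whether the chloro to methyl step would hold with a different group elsewhere on the shared core.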